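Chloro for fluoro on the aryl amide nitrogen substituent

The compounds below may be only part of what the source reports. "The series", "measured", "known", "first", "only" and "open" are said of these compounds alone.

Three compounds of the series are measured in an ADME assay on WI-38 cells (Homo sapiens) for cytotoxicity, read by MTT assay, with a stated time of 72 h; on this read-out higher numbers stand for weaker inhibition and lower numbers for stronger inhibition. Compound 1 `CCN(CC)CCn1cnnc1-c1cc(Oc2ccc(NC(=O)Nc3ccc(F)c(Cl)c3)cc2F)ccn1` gives 28700 nM, compound 2 `CN(C)CCCn1cnnc1-c1cc(Oc2ccc(NC(=O)Nc3cccc(C(F)(F)F)c3)cc2F)ccn1` gives 11600 nM, and compound 3 `CN(C)CCCn1cnnc1-c1cc(Oc2ccc(NC(=O)Nc3ccc(F)c(F)c3)cc2F)ccn1` gives 15300 nM. On these numbers compound 3 stands second highest of three; its nearest neighbour is compound 2 and its furthest compound 1, and both gaps lie within the scatter. Compound 4 `CN(C)CCCn1cnnc1-c1cc(Oc2ccc(NC(=O)Nc3ccc(F)c(Cl)c3)cc2F)ccn1` differs from compound 3 by chloro in place of fluoro on an aromatic carbon. Among the compounds with values here, the only measured step touching the same region is a 1.3-fold higher number from compound 2 to compound 3 (0.12 log units; within the scatter), which lies within the scatter. Compound 1 carries the same 3-chloro-4-fluorophenyl group but differs from compound 4 elsewhere as well, so its value bears only loosely. Compound 4 is therefore expected to show a 1.2-fold higher number from compound 3 to compound 4 (0.07 log units; within the scatter), nothing beyond the scatter, with an estimate of 18000 nM, between 8000 nM and 40000 nM.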

Compound 4, half-maximal inhibitory concentration: 5370 nM
The estimate for compound 4 lay 3.4-fold (0.53 log units) above the measured number, and the stated range ends above it.
By their numbers in this assay, from the lowest: compound 4; then compounds 2, 3 and 1 (each within the scatter of the next, the first and the last beyond it).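

In this assay, within the data shown here, chloro in place of fluoro on the aromatic carbon gives the first step in this region beyond the scatter (a 2.8-fold lower number from compound 3 to compound 4 (0.45 log units; beyond the scatter)), and 3-chloro-4-fluorophenyl in place of 3-(trifluoromethyl)phenyl also moves the number beyond it (a 2.2-fold lower number from compound 2 to compound 4 (0.33 log units; beyond the scatter)). With the 3-chloro-4-fluorophenyl group held constant, (dimethylamino)methyl in place of diethylamino gives a step beyond the scatter as well (a 5.3-fold lower number from compound 1 to compound 4 (0.73 log units; beyond the scatter)). No evidence at hand accounts for these steps. Open, as far as these compounds go, are bromo or methyl on this aromatic carbon, and whether the chloro step recurs with the diethylamino chain.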